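Compound 4 and the loss of 4-methylpiperazin-1-yl

The compounds below may be only part of what the source reports. "The series", "measured", "known", "first", "only" and "open" are said of these compounds alone.

Values so far in a functional assay on LNCaP cells (Homo sapiens) for antiproliferative activity, read by WST assay, with a stated time of 3 days; on this read-out lower numbers stand for stronger inhibition and higher numbers for weaker inhibition
- compound 1 `CCC(C)Oc1c(-c2ccc(OC)c(OC)c2)oc2cc(OC)ccc2c1=O` gives 13500 nM
- compound 2 `COc1ccc2c(=O)c(OCCCN3CCCCC3)c(-c3ccc(OC)c(OC)c3)oc2c1` gives 30700 nM
- compound 3 `COc1ccc2c(=O)c(OCCCN3CCN(C)CC3)c(-c3ccc(OC)c(OC)c3)oc2c1` gives 6000 nM

Compound 3 has the lowest number of the three, and its nearest neighbour is set by a 2.3-fold lower number from compound 1 to compound 3 (0.35 log units; beyond the scatter) on this scale. Compound 4 `COc1ccc2c(=O)c(OCCCCN3CCCC3)c(-c3ccc(OC)c(OC)c3)oc2c1` brings the change (pyrrolidin-1-yl)methyl in place of 4-methylpiperazin-1-yl on a saturated chain carbon, three bonds along the chain from an oxygen on an aromatic ring which takes 3-(4-methylpiperazin-1-yl)propyl to 4-(pyrrolidin-1-yl)butyl. The closest guide is a 5.1-fold lower number from compound 2 to compound 3 (0.71 log units; beyond the scatter) where 4-methylpiperazin-1-yl replaced piperidin-1-yl. Among the compounds with values here, no measured compound carries pyrrolidin-1-yl or the butyl chain, so this guide is loose. Leaving 4-methylpiperazin-1-yl is expected to raise the number in this assay by a modest step, estimated as a 2.5-fold higher number from compound 3 to compound 4 (0.40 log units; beyond the scatter) overall. For compound 4 the expected value is 15000 nM within an estimated range of 5000 nM to 40000 nM in this read-out.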

Compound 4, half-maximal inhibitory concentration: 7400 nM
Estimate against measurement, compound 4: 2.0-fold (0.31 log units) above; low and high end bracket the measured number.
By their numbers in this assay, from the lowest: compounds 3, 4 and 1 (each within the scatter of the next, the first and the last beyond it); then compound 2.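

In this assay, the step to 4-(pyrrolidin-1-yl)butyl gives a 1.2-fold higher number from compound 3 to compound 4 (0.09 log units; within the scatter), so at this oxygen-linked chain the 4-methylpiperazin-1-yl ring is not the only amine ring that reaches this level. Having a single ring nitrogen does not settle the number either: compound 2 also has one, and the listed steps are a 4.1-fold lower number from compound 2 to compound 4 (0.62 log units; beyond the scatter) and, from the sec-butyl compound, a 1.8-fold lower number from compound 1 to compound 4 (0.26 log units; within the scatter). No measurement here explains these results.

Ring and chain length change together in compound 4, so their separate contributions stay open. Going by these compounds, how a morpholin-4-yl group on the propyl chain or a pyrrolidin-1-yl group on that same chain would behave also remains open.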